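The source may hold more compounds than are shown below. What is called first, only, known or untested is meant among the compounds shown, and "the series" means these compounds.

Measured so far:
compound 1, `Cc1cc(=O)c2c(O)cc(OCc3ccc(Br)cc3)c([C@H]3CCN(C)C[C@H]3O)c2o1` — in a functional assay on PC-3 cells (Homo sapiens) for inhibition, read by MTT assay, with a stated time of 48 h, tested at 10 uM (a lower number here means less inhibition of growth, a higher number more inhibition of growth at the concentration tested), compound 1 gives 17%
compound 2, `Cc1cc(=O)c2c(O)c(CN3CCCC3)c(O)c([C@H]3CCN(C)C[C@H]3O)c2o1` — in this assay compound 2 gives 10%

Among the measured compounds shown here, only two compounds carry a number in this assay, and the two numbers fall within the scatter of each other, so compound 2 cannot be set apart from compound 1; both show weak inhibition of growth at the tested concentration.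

Compound 3, `Cc1cc(=O)c2c(O)c(CN3CCCCC3)c(O)c([C@H]3CCN(C)C[C@H]3O)c2o1`, is not yet measured. It differs from compound 2 in one place: piperidin-1-yl in place of pyrrolidin-1-yl on a saturated chain carbon bound to an aromatic carbon. The five-membered non-aromatic ring with 1 hetero atom gives way to the six-membered one, with no change in hydrogen-bond donors, acceptors or charge.

For the measured compounds named here, no measured pair shows the effect of such a change. With nothing to argue for a move in either direction, the step from compound 2 to compound 3 is expected to stay within the scatter, as a number 2 percentage points higher from compound 2 to compound 3 (within the scatter) in this assay. Compound 3 is therefore estimated at 12% in this assay, in the range 0% to 28%.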

Compound 3, percent growth inhibition at one concentration: 14%
For compound 3 the middle estimate is 2 percentage points below the measured one; measured number inside the range.
By their numbers in this assay, from the lowest: compounds 2, 3 and 1 (each within the scatter of the next).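

Among the compounds shown here, replacing pyrrolidin-1-yl with piperidin-1-yl on a saturated chain carbon bound to an aromatic carbon gives the first comparison that differs in one place: in this assay the change reads as a number 4 percentage points higher from compound 2 to compound 3 (within the scatter) and so cannot be told apart from repeat-measurement noise. At this place, the five-membered and six-membered non-aromatic rings therefore do not separate the two compounds at the tested concentration, and growth inhibition is weak with either ring. No supporting data bear on this result.

Still open, on these data alone, is whether an open-chain amine such as diethylamino, or a ring with a second hetero atom such as morpholin-4-yl, would shift the number at this place. As far as these compounds go, it is also open whether the two rings would remain indistinguishable at other concentrations.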